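A few compounds are considered here, and "the series" means these few. Any claim that something is new, unique, unknown or untested is made for them only; others in the source may bear on it.

In a functional assay (aorta) with Oryctolagus cuniculus as the target (a higher number here means weaker binding, a lower number tighter binding), compound 1 (`CCCCc1nc2ccccc2n1Cc1cc(Cl)c(O)c(Cl)c1`) gives 63.1 nM and compound 2 (`Cc1ccnc2c1nc(C(C)C)n2Cc1ccc(-c2ccccc2C(=O)O)cc1`) gives 31.6 nM in the same test. Within the data shown here, these two values lie within the usual scatter of each other, so compound 2 stands level with compound 1 on the numbers so far. Compound 3 (`COCc1nc2c(C)ccnc2n1Cc1ccc(-c2ccccc2C(=O)O)cc1`) differs from compound 2 in one place. The change is methoxymethyl in place of isopropyl on an aromatic carbon with methoxymethyl in place of isopropyl on an aromatic carbon, between two ring nitrogen atoms. Among the measured compounds shown here, no measured pair shows a change at this place, so there is no direct guide to the size of the step. A modest move toward a higher number in this assay is expected, and it may not clear the scatter. The estimated change is a 2.2-fold higher number from compound 2 to compound 3 (0.35 log units; beyond the scatter) on this reading. In this assay the estimate for compound 3 is 70 nM with an expected range from 18 nM to 280 nM for now.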

Compound 3, dissociation constant: 79.4 nM
For compound 3 the middle estimate is 1.1-fold (0.05 log units) below the measured one, and the stated range covers the measured number.
By their numbers in this assay, from the lowest: compounds 2, 1 and 3 (each within the scatter of the next, the first and the last beyond it).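

At the position on an aromatic carbon of a five-membered aromatic ring with 2 nitrogen, the series now has its first direct reading: in this assay methoxymethyl in place of isopropyl gives a 2.5-fold higher number from compound 2 to compound 3 (0.40 log units; beyond the scatter) as a modest step. This step comes with the count of 3 heavy atoms unchanged, while oxygen replaces one carbon and the hydrogen-bond acceptor count goes from 0 to 1, and a single pair cannot show which of these differences matters. No measurement in hand explains the step.

Still open, on these data alone, is whether an ethyl group, a hydroxymethyl group or an amine at this position would stay level with isopropyl or move further from it. Also open, as far as these compounds go, is whether the step keeps its size when the methyl on the shared core is replaced by chlorine.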